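A Dimethylpiperazine Variant of a Secretagogue Receptor Agonist

The source may report more compounds than this note shows. Statements on the series, on what has been measured and on what is new or still open speak of the compounds shown alone.

Compound 3 `COc1cc2c(cc1N1CCN[C@@H](C)C1)N(S(=O)(=O)c1ccc(-c3ccccn3)s1)CC2` gives 3.16 nM in a functional assay for agonist activity at growth hormone secretagogue receptor type 1 (Homo sapiens), read by FLIPR; a higher number here means that more compound is needed for the effect, a lower number that less compound is needed. Among the three measured compounds it holds the second highest number; its nearest neighbour is compound 2 `COc1cc2c(cc1N1C[C@@H](C)N[C@@H](C)C1)N(S(=O)(=O)c1ccc(-c3ccon3)s1)CC2`, which gives 2.51 nM, a difference within the usual scatter, while the furthest is compound 1 `COc1cc2c(cc1N1C[C@@H](C)N[C@@H](C)C1)N(S(=O)(=O)c1cccc(-c3ccccn3)c1)CC2`, which gives 20 nM, a gap beyond the scatter. Compound 4 `COc1cc2c(cc1N1CCNC(C)(C)C1)N(S(=O)(=O)c1ccc(-c3ccccn3)s1)CC2` has not been measured. It differs from compound 3 by 3,3-dimethylpiperazin-1-yl in place of 3-methylpiperazin-1-yl on an aromatic carbon. For the measured compounds named here, no comparable step exists among the measured compounds, so the size of the change can only be estimated; the step is expected to be a 1.6-fold higher number from compound 3 to compound 4 (0.20 log units; within the scatter), a small rise that need not exceed the scatter. Compound 4 is therefore estimated at 5 nM, with a range from 1.5 nM to 20 nM.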

Compound 4, half-maximal effective concentration: 15.9 nM
Estimate against measurement, compound 4: 3.2-fold (0.50 log units) below; measured number inside the range.
By their numbers in this assay, from the lowest: compounds 2 and 3 (each within the scatter of the next); then compounds 4 and 1 (each within the scatter of the next).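

Replacing 3-methylpiperazin-1-yl with 3,3-dimethylpiperazin-1-yl on the aromatic carbon ortho to the methoxy group gives a 5.0-fold higher number from compound 3 to compound 4 (0.70 log units; beyond the scatter) in this assay. For the compounds shown here, this is the first comparison here that differs in one place, and it shows that this position is sensitive to a small change in the piperazine. The change adds one carbon and removes the defined stereocentre, and no measured property is available to explain the step. Still open, from the compounds shown here alone, is how a plain piperazin-1-yl or a morpholine would read at this carbon.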